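The source may hold more compounds than are shown below. What is called first, only, known or untested is meant among the compounds shown, and "the series" means these compounds.

Within the data shown here, in a functional assay on BT-549 cells (Homo sapiens) for inhibition, read by sulforhodamine B assay, with a stated time of 48 h (on this read-out higher numbers stand for weaker inhibition of growth and lower numbers for stronger inhibition of growth), compound 1 `O=C(Cc1csc2nc(-c3ccc(Br)cc3)cn12)N/N=C/c1ccccc1` gives 49000 nM and compound 2 `O=C(Cc1csc2nc(-c3ccc(Br)cc3)cn12)N/N=C/c1ccccc1O` gives 22400 nM, the lower of the two numbers so far. Compound 3 `O=C(Cc1csc2nc(-c3ccc(Br)cc3)cn12)N/N=C/c1ccc(O)cc1` differs from compound 2 as follows: 4-hydroxyphenyl in place of 2-hydroxyphenyl on a carbon with a double bond to nitrogen. Among the measured compounds shown here, one measured step bears on this, a 2.2-fold lower number from compound 1 to compound 2 (0.34 log units; beyond the scatter), a modest change for hydroxy in place of hydrogen on an aromatic carbon. For the measured compounds named here, no measured compound carries 4-hydroxyphenyl, so only a small move toward a higher number in this assay is expected, possibly none beyond the scatter. The expected change is a 1.3-fold higher number from compound 2 to compound 3 (0.13 log units; within the scatter). The estimated value for compound 3 is 30000 nM, with an expected range of 14000 nM to 60000 nM.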

Compound 3, concentration for total growth inhibition: 56200 nM
Beside the measured number, compound 3's estimate is 1.9-fold (0.27 log units) below it, within the range that was stated.
By their numbers in this assay, from the lowest: compound 2; then compounds 1 and 3 (each within the scatter of the next).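

In this assay, the effect of hydroxy depends on where it sits on the aromatic ring: 4-hydroxyphenyl in place of 2-hydroxyphenyl gives a 2.5-fold higher number from compound 2 to compound 3 (0.40 log units; beyond the scatter) and cancels the advantage of compound 2. Compared with the unsubstituted phenyl of compound 1, 4-hydroxyphenyl gives a 1.1-fold higher number from compound 1 to compound 3 (0.06 log units; within the scatter), so hydroxy alone does not lower the number. Going by these compounds, whether an amine or a methoxy group in place of the hydroxy of compound 2 would keep its lower number remains open. Nothing available explains the difference between the two hydroxyphenyl groups.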